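Pyrrolidinyl to Piperidinyl Swap on a Thiocarbonyl Carbon

This account rests on a few compounds, and the source may have more. Where it says the series, first, only, none or still open, it means among the compounds named here.

Compound 2 `Cc1ccc2c(=O)c(CSC(=S)N3CCCC3)coc2c1` carries a pyrrolidin-1-yl group on its thiocarbonyl carbon, and in a functional assay on HeLa cells (Homo sapiens) for antiproliferative activity, read by MTT assay, with a stated time of 72 h (a higher number here means a weaker inhibitor, a lower number a stronger inhibitor), compound 2 gives 4400 nM. Compound 1 `Cc1ccc2c(=O)c(CSC(=S)N3CCCCC3)coc2c1` differs from it by piperidin-1-yl in place of pyrrolidin-1-yl on a thiocarbonyl carbon. In this assay compound 1 gives only a limit, > 25000 nM. The step of an at least 5.6-fold higher number from compound 2 to compound 1 (0.75 log units; beyond the scatter) is thus known only as a bound, because the limit of > 25000 nM in this assay, at which 1 of the 3 values shown sits, caps what can be read. Compound 3 `COc1ccc2occ(CSC(=S)N3CCCC3)c(=O)c2c1` keeps the pyrrolidin-1-yl group of compound 2 but rests on another core; the difference between the two cores is not broken down here. In this assay compound 3 gives 12100 nM, the highest of the two numbers. Compound 4 `COc1ccc2occ(CSC(=S)N3CCCCC3)c(=O)c2c1` has not been measured; it differs from compound 3 by piperidin-1-yl in place of pyrrolidin-1-yl on a thiocarbonyl carbon, the same change that separates compound 1 from compound 2, at the same place. That change produced an at least 5.6-fold higher number from compound 2 to compound 1 (0.75 log units; beyond the scatter). On that basis a step of at least comparable size is expected, a 4.1-fold higher number from compound 3 to compound 4 (0.62 log units; beyond the scatter). Compound 4 is therefore estimated at 50000 nM, with a range from 15000 nM to 200000 nM, and a limit rather than a number is likely.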

Compound 4, half-maximal inhibitory concentration: 3500 nM
Compound 4: the middle estimate sits 14-fold (1.15 log units) above what was measured; the whole stated range lies above it.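

In this assay, the same replacement of pyrrolidin-1-yl by piperidin-1-yl on a thiocarbonyl carbon gives a 3.5-fold lower number from compound 3 to compound 4 (0.54 log units; beyond the scatter), so on the core of compound 3 the step runs the opposite way to the step on the core of compound 2, and the change does not carry from one core to the other in this series: the same change on two cores in this assay, an at least 5.6-fold higher number (0.75 log units; beyond the scatter) from compound 2 to compound 1 and a 3.5-fold lower number (0.54 log units; beyond the scatter) from compound 3 to compound 4, at least 19-fold (1.29 log units) apart, beyond the scatter of two such steps The size of that gap is itself only a bound, since compound 1 gives a limit rather than a number: the limit of > 25000 nM in this assay, at which 1 of the 4 values shown sits. Two pairs show that the outcome of this change depends on the core here, but they set no rule for other cores and do not show which feature of the two cores goes with the reversal.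

The compounds shown leave open how a morpholin-4-yl or a diethylamino group on the thiocarbonyl carbon would compare with these two rings on either core. They also leave open which way the step would run on a core bearing a chlorine atom.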